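The source may hold more compounds than are shown below. What is called first, only, known or untested is meant among the compounds shown, and "the series" means these compounds.

In an ADME assay on HEK-293T cells (Homo sapiens) for inhibition, read by CCK-8 assay, with a stated time of 48 h, tested at 20 uM (on this read-out higher numbers stand for more inhibition of growth at the one concentration tested and lower numbers for less inhibition of growth), compound 3 (`N#C/C(=C\c1ccccc1OS(=O)(=O)c1ccc([N+](=O)[O-])cc1)C(=O)Nc1nnc(Cc2ccc(Cl)cc2)s1`) gives 19%. That number lies within the scatter of both compound 1 (`N#C/C(=C\c1ccccc1OS(=O)(=O)c1ccc(Cl)cc1)C(=O)Nc1nnc(Cc2ccccc2)s1`), at 25%, and compound 2 (`N#C/C(=C\c1ccccc1OS(=O)(=O)c1ccc(Cl)cc1)C(=O)Nc1nnc(-c2cccc(F)c2)s1`), at 29%, so the three cannot be ranked. Compound 4 (`N#C/C(=C\c1ccccc1OS(=O)(=O)c1ccc(Cl)cc1)C(=O)Nc1nnc(Cc2ccc(Cl)cc2)s1`) differs from compound 3 in a single place: chloro in place of nitro on an aromatic carbon, para to a large group. Among the compounds with values here, no measured step covers this exchange. Within the data shown here, the only step available, a number 4 percentage points higher from compound 1 to compound 2 (within the scatter), lies within the scatter and concerns a different place, so it bears on the question only indirectly. Compound 1 and compound 2 both carry the chloro group that compound 4 gains, yet their values do not separate from that of compound 3, which carries nitro. No change beyond the scatter is therefore expected in this assay, and the expected step of a number 4 percentage points higher from compound 3 to compound 4 (within the scatter) is small. The estimate for compound 4 is 23%, with an expected range of 12% to 35%.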

Compound 4, percent growth inhibition at one concentration: 14%
Estimate against measurement, compound 4: 9 percentage points above; measured number inside the range.
By their numbers in this assay, from the lowest: compounds 4, 3, 1 and 2 (each within the scatter of the next, the first and the last beyond it).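

In this assay, within the data shown here, the change from (4-nitrophenyl)sulfonyl to (4-chlorophenyl)sulfonyl brings a number 5 percentage points lower from compound 3 to compound 4 (within the scatter) and gives the first direct reading at this place: nitro and chloro do not separate here. Steps beyond the scatter appear only at a different place, on the group carried by the thiadiazole side of the shared core, where chloro in place of hydrogen brings a number 11 percentage points lower from compound 1 to compound 4 (beyond the scatter) and 4-chlorobenzyl in place of 3-fluorophenyl brings a number 15 percentage points lower from compound 2 to compound 4 (beyond the scatter), both modest. Nothing measured here accounts for these steps.

Going by these compounds, whether an amine or a carboxylic acid in place of nitro on this aromatic carbon would also stay within the scatter remains open. The compounds shown also leave open whether the step from hydrogen to chloro on the benzyl group recurs when nitro takes the place of chloro on the sulfonyl side.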